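Swapping a piperidine for a carbamate and cell toxicity

A few compounds are considered here, and "the series" means these few. Any claim that something is new, unique, unknown or untested is made for them only; others in the source may bear on it.

Compound 2 `O=C1O[C@@H](CN2CCC(O)CC2)CN1c1ccc(-n2cc(-c3ccccn3)cn2)c(F)c1` is one of three related compounds tested in an ADME assay on HEK293-A cells (Homo sapiens) for cytotoxicity, read by MTT assay, with a stated time of 48 h; on this read-out lower numbers stand for stronger inhibition and higher numbers for weaker inhibition. For compound 2 the result is a limit, > 400 ug/mL, not a number. Compound 1 `O=C1O[C@@H](CN2CCCCC2)CN1c1ccc(-n2cc(-c3ccccn3)cn2)c(F)c1` likewise reaches only a limit, > 400 ug/mL. Compound 3 `O=C1O[C@@H](Cn2ccnn2)CN1c1ccc(-n2cc(-c3ccccn3)cn2)c(F)c1` gives 225 ug/mL. Compound 2 thus stands at the limit of > 400 ug/mL in this assay, at which 2 of the 3 values shown sit. The step of an at least 1.7-fold lower number from compound 2 to compound 3 (0.24 log units; that floor lies within the scatter) and the step of an at least 1.7-fold lower number from compound 1 to compound 3 (0.24 log units; that floor lies within the scatter) each have a floor within the scatter, and the step that the two limits leave unreadable from compound 1 to compound 2 cannot be read. Compound 4 `COC(=O)NC[C@H]1CN(c2ccc(-n3cc(-c4ccccn4)cn3)c(F)c2)C(=O)O1` carries the change ((methoxycarbonyl)amino in place of 4-hydroxypiperidin-1-yl on a saturated chain carbon bound to a saturated ring carbon). For the measured compounds named here, no measured step matches this change, so the expected step of a number no higher from compound 2 to compound 4 (the limit leaves the size open) is none beyond the scatter. Compound 4 is therefore estimated at about 400 ug/mL, within a range from 200 ug/mL to 800 ug/mL.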

Compound 4, half-maximal inhibitory concentration: 306 ug/mL
The estimate for compound 4 lay 1.3-fold (0.12 log units) above the measured number; the range from low to high includes it.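

Even without a ring, (methoxycarbonyl)amino on a saturated chain carbon bound to a saturated ring carbon gives a measured number. Set against the two piperidine compounds, the result is only a floor, an at least 1.3-fold lower number from compound 2 to compound 4 (0.11 log units; that floor lies within the scatter) and an at least 1.3-fold lower number from compound 1 to compound 4 (0.11 log units; that floor lies within the scatter), so a true shift is neither shown nor excluded. In this assay, a 1.4-fold higher number from compound 3 to compound 4 (0.13 log units; within the scatter) leaves this group and 1H-1,2,3-triazol-1-yl indistinguishable. The step between the two piperidine compounds cannot be read, as both results are limits. Going by these compounds, how a primary amine or a carboxylic acid at this place would read remains open.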